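The source may report more compounds than this note shows. Statements on the series, on what has been measured and on what is new or still open speak of the compounds shown alone.

Compound 1 `CN(C)Cc1ccc2nc(NC(=O)N/N=C/c3c[nH]c4ccccc34)sc2c1` gives 1190 nM
Compound 2 `CN(C)Cc1ccc2nc(NC(=O)N/N=C/c3cn(Cc4ccc(Cl)cc4)c4ccccc34)sc2c1` gives 880 nM
Compound 3 `Cc1ccc(Cn2cc(/C=N/NC(=O)Nc3nc4ccc(CN(C)C)cc4s3)c3ccccc32)cc1` gives 1220 nM

These values all come from a functional assay on MDA-MB-231 cells (Homo sapiens) for cytotoxicity, read by MTT assay, with a stated time of 72 h (on this read-out higher numbers stand for weaker inhibition and lower numbers for stronger inhibition), and lie within the usual scatter of one another. Compound 3 at 1220 nM therefore cannot be told apart from the other two.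

The next compound is compound 4 `CN(C)Cc1ccc2nc(NC(=O)N/N=C/c3cn(Cc4cccc(Cl)c4)c4ccccc34)sc2c1` and the change is 3-chlorophenyl in place of 4-methylphenyl on a saturated chain carbon bound to an aromatic nitrogen or, read one bond further out, 4-methylbenzyl to 3-chlorobenzyl. Going by the values given here, three measured steps bear on this. Putting 4-chlorobenzyl on the aromatic nitrogen gives a 1.4-fold lower number from compound 1 to compound 2 (0.13 log units; within the scatter) and putting 4-methylbenzyl there gives a 1.0-fold higher number from compound 1 to compound 3 (0.01 log units; within the scatter) while methyl in place of chloro gives a 1.4-fold higher number from compound 2 to compound 3 (0.14 log units; within the scatter) and none of these leaves the scatter. Among the compounds with values here, no measured compound carries 3-chlorobenzyl, so that group is untested. Within the data shown here, compound 2 at 880 nM is the only measured compound with a chlorobenzyl group, so the estimate leans slightly toward it. The expected result is a 1.2-fold lower number from compound 3 to compound 4 (0.09 log units; within the scatter) and no step beyond the scatter is expected in this assay for this change. For compound 4 the estimated value is 1000 nM with an expected range from 500 nM to 2000 nM at the outside.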

Compound 4, half-maximal inhibitory concentration: 1140 nM
Estimate against measurement, compound 4: 1.1-fold (0.06 log units) below; low and high end bracket the measured number.
By their numbers in this assay, from the lowest: compounds 2, 4, 1 and 3 (each within the scatter of the next).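

Compound 4 adds a second chlorobenzyl group to the set, and in this assay 3-chlorophenyl in place of 4-chlorophenyl gives a 1.3-fold higher number from compound 2 to compound 4 (0.11 log units; within the scatter) on the saturated chain carbon bound to the aromatic nitrogen. Against the methyl-bearing group, the change to 3-chlorophenyl gives a 1.1-fold lower number from compound 3 to compound 4 (0.03 log units; within the scatter) and, against the bare aromatic nitrogen, adding 3-chlorobenzyl gives a 1.0-fold lower number from compound 1 to compound 4 (0.02 log units; within the scatter) within the same read-out. All three steps lie within the scatter, so this position has now accepted three substituted benzyl groups without a readable difference from hydrogen or among themselves, and no outside measurement bears on this result.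

From the compounds shown here alone, only chloro and methyl appear on this benzyl ring, so an amine or a carboxylic acid there remains open, as does a longer chain in place of the benzyl group on the aromatic nitrogen. Whether any of these would leave the scatter cannot be said from these compounds.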